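A Nitrophenyl in Place of a Dimethylphenyl

A few compounds are considered here, and "the series" means these few. Any claim that something is new, unique, unknown or untested is made for them only; others in the source may bear on it.

In a functional assay on HCT-116 cells (Homo sapiens) for inhibition, read by MTT assay, with a stated time of 72 h (a higher number here means a weaker inhibitor, a lower number a stronger inhibitor), three compounds have been measured:
Compound 1 `Cc1ccc2c(c1)/C(=N/NC(=S)N1CCN(c3ccccc3)CC1)C(=O)N2` gives 9480 nM
Compound 2 `O=C1Nc2c(Br)cc(Br)cc2/C1=N/NC(=S)N1CCN(c2ccccc2)CC1` gives 6320 nM
Compound 3 `Cc1ccc(N2CCN(C(=S)N/N=C3\C(=O)Nc4ccc(Cl)cc43)CC2)c(C)c1` gives 7180 nM

Compound 3 sits close to the other two: its number lies within the usual scatter of both compound 2 and compound 1, so none of the three can be called stronger or weaker than another in this assay. Compound 4 `O=C1Nc2ccc(Cl)cc2/C1=N/NC(=S)N1CCN(c2ccccc2[N+](=O)[O-])CC1` keeps the core of compound 3 and differs in one place: 2-nitrophenyl in place of 2,4-dimethylphenyl on an amine nitrogen in a ring. Among the measured compounds shown here, no measured pair shows what such an exchange does in this assay. For the measured compounds named here, with no step to rest on, the expectation is a 1.0-fold higher number from compound 3 to compound 4 (0.02 log units; within the scatter), that is, nothing beyond the scatter in either direction. Compound 4 is therefore expected to give about 7500 nM in this assay, within a range from 2500 nM to 22000 nM.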

Compound 4, half-maximal inhibitory concentration: 4570 nM
For compound 4 the middle estimate is 1.6-fold (0.22 log units) above the measured one, and the stated range covers the measured number.
By their numbers in this assay, from the lowest: compounds 4, 2, 3 and 1 (each within the scatter of the next, the first and the last beyond it).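

In this assay, putting 2-nitrophenyl in place of 2,4-dimethylphenyl on the amine nitrogen in the ring gives a 1.6-fold lower number from compound 3 to compound 4 (0.20 log units; within the scatter). This first step at this position shows that hydrogen-bond acceptors can enter with the nitro group while the number remains within the scatter. No measurement shown here explains this result.

On these data alone, it remains open whether an amine or a carboxylic acid on this phenyl ring would give a step beyond the scatter. As far as these compounds go, it is also open whether the same exchange gives a similar step on the cores of compound 1 and compound 2.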